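The compounds below may be only part of what the source reports. "The series", "measured", "known", "first", "only" and "open" are said of these compounds alone.

In a functional assay on HT-29 cells (Homo sapiens) for cytotoxicity, read by resazurin assay, with a stated time of 48 h (a lower number here means that less compound is needed, a higher number that more compound is needed for the effect), compound 1 (`COc1ccc(S(=O)(=O)Nc2ccc(-c3nc4cc(NS(=O)(=O)c5ccc(OC)cc5)ccc4o3)cc2)cc1`) gives 40000 nM against compound 2 (`O=S(=O)(Nc1ccc(-c2nc3cc(NS(=O)(=O)c4ccc(Cl)s4)ccc3o2)cc1)c1ccc(Cl)c(C(F)(F)F)c1`) at 21000 nM and compound 3 (`COc1c(Br)cccc1C(=O)Nc1ccc(Sc2nc3ccccc3s2)cc1`) at 30000 nM in the same test, so all three sit within the usual scatter of one another. Compound 4 (`COc1ccc(S(=O)(=O)Nc2ccc3oc(-c4ccc(NC(=O)C5CCN(C(C)=O)CC5)cc4)nc3c2)cc1`) has not yet been measured. For the measured compounds named here, it keeps the core of compound 1 but carries (1-acetylpiperidin-4-yl)carbonyl in place of (4-methoxyphenyl)sulfonyl on a nitrogen on an aromatic ring as its one change. Going by the values given here, no measured pair isolates this swap, and the only guide is the level of compound 1 at 40000 nM so no step beyond the scatter is expected in this assay for this swap. The expected size is a 1.3-fold lower number from compound 1 to compound 4 (0.12 log units; within the scatter) and lies within the scatter. Compound 4 is expected at an estimated 30000 nM with a likely range from 9000 nM to 90000 nM in that test.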

Compound 4, half-maximal effective concentration: 16000 nM
Compound 4: middle estimate off by 1.9-fold (0.27 log units), on the high side, within the range that was stated.
By their numbers in this assay, from the lowest: compounds 4, 2, 3 and 1 (each within the scatter of the next, the first and the last beyond it).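

In this assay, for the compounds shown here, placing (1-acetylpiperidin-4-yl)carbonyl in place of (4-methoxyphenyl)sulfonyl on a nitrogen on an aromatic ring gives a 2.5-fold lower number from compound 1 to compound 4 (0.40 log units; beyond the scatter) as the first single-place step in this set. It shows that changing the group at this position can move the number beyond the scatter, though only modestly. No available evidence explains this step.

The compounds shown do not separate the part played by the carbonyl link from that of the ring it carries. As far as these compounds go, a plain acetyl group on this nitrogen, or a free amine on the ring in place of the acetyl, also remains untested here.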